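Swapping the triazole substituent: aryl to anilide tether

The compounds below may be only part of what the source reports. "The series", "measured", "known", "first", "only" and "open" are said of these compounds alone.

Measured so far:
compound 1 `CCCCCCCCn1cc(COC2(C(F)(F)F)Oc3ccccc3C=C2C(=O)OCC)nn1` — > 150000 nM
compound 2 `CCOC(=O)C1=Cc2ccccc2OC1(OCc1cn(-c2ccc(F)c(Cl)c2)nn1)C(F)(F)F` — 26300 nM

In a functional assay on A549 cells (Homo sapiens) for inhibition, read by MTT assay, with a stated time of 24 h (a higher number here means a weaker inhibitor, a lower number a stronger inhibitor), compound 1 does not reach a number; it sits at the limit > 150000 nM. For the measured compounds named here, compound 2 gives 26300 nM, the only numeric value shown. The other value, that of compound 1, is a limit (the limit of > 150000 nM in this assay, at which 1 of the 2 values shown sits). Going by the values given here, the one measured step is an at least 5.7-fold lower number from compound 1 to compound 2 (0.75 log units; beyond the scatter), so exchanging the group on the ring nitrogen has moved the read-out beyond the scatter at least once.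

Compound 3 `CCOC(=O)C1=Cc2ccccc2OC1(OCc1cn(CC(=O)Nc2ccc(I)cc2Cl)nn1)C(F)(F)F` carries a further exchange at the same position: ((2-chloro-4-iodophenyl)carbamoyl)methyl in place of 3-chloro-4-fluorophenyl on an aromatic nitrogen. Among the compounds with values here, the only step that bears on it is the one from compound 1 to compound 2, which concerned an alkyl chain giving way to an aryl ring rather than an aryl ring giving way to an amide-linked aryl. That step shows the position is sensitive but gives no direction for the present change, so no step beyond the scatter is confidently expected, with wide uncertainty. Compound 3 is therefore estimated at 30000 nM, within 8000 nM to 110000 nM. The expected step is a 1.1-fold higher number from compound 2 to compound 3 (0.06 log units; within the scatter).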

Compound 3, half-maximal inhibitory concentration: 22300 nM
Compound 3: the middle estimate sits 1.3-fold (0.13 log units) above what was measured, within the range that was stated.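

In this assay the exchange gives a 1.2-fold lower number from compound 2 to compound 3 (0.07 log units; within the scatter) even though the group that enters has 12 heavy atoms in place of 8 and adds a hydrogen-bond donor and a hydrogen-bond acceptor, so this position accepts an aromatic ring held on a carbamoyl-containing tether as well as one attached directly to the ring nitrogen. The comparison with the alkyl compound gives an at least 6.7-fold lower number from compound 1 to compound 3 (0.82 log units; beyond the scatter) and makes compound 3 the second of the compounds shown, after compound 2, in which a group carrying an aromatic ring stands clear of the octyl chain, and neither of the three goes against this. Compound 1 marks a limit and not a number, and this holds for both steps that start from it: the limit of > 150000 nM in this assay, at which 1 of the 3 values shown sits.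

The tether and the halogens on the aromatic ring change together from compound 2 to compound 3, and the contribution of each alone stays unread. Also open, from the compounds shown here alone, is how the read-out would respond to an unsubstituted phenyl ring on the same tether, or to a carboxylic acid or an amine in place of the aromatic ring.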